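Swapping fluoro for benzyloxy on the shared core

A few compounds are considered here, and "the series" means these few. Any claim that something is new, unique, unknown or untested is made for them only; others in the source may bear on it.

Compound 1 `Fc1ccc(C2=NN(C(=S)Nc3ccccc3)C(c3ccc4c(c3)OCCO4)C2)cc1`: 61200 nM
Compound 2 `S=C(Nc1ccccc1)N1N=C(c2ccccc2Br)CC1c1ccc2c(c1)OCCO2`: 195000 nM
Compound 3 `Cc1ccc(C2=NN(C(=S)Nc3ccccc3)C(c3ccc4c(c3)OCCO4)C2)cc1C`: 144000 nM

In a functional assay on HCT-116 cells (Homo sapiens) for antiproliferative activity, read by MTT assay, with a stated time of 48 h (a higher number here means a weaker inhibitor of growth, a lower number a stronger inhibitor of growth), compound 1 gives 61200 nM, the lowest of the three numbers. The step of a 3.2-fold higher number from compound 1 to compound 2 (0.50 log units; beyond the scatter) and the step of a 2.4-fold higher number from compound 1 to compound 3 (0.37 log units; beyond the scatter) both raise the number, while compound 2 and compound 3 sit within the scatter of each other. Compound 4 `S=C(Nc1ccccc1)N1N=C(c2ccc(OCc3ccccc3)cc2)CC1c1ccc2c(c1)OCCO2` differs from compound 1 by benzyloxy in place of fluoro on an aromatic carbon. For the measured compounds named here, no measured step changes this position in this way; the two measured steps change the ring on the carbon double-bonded to nitrogen, and both were modest and upward. A modest upward step a 1.5-fold higher number from compound 1 to compound 4 (0.17 log units; within the scatter) is therefore expected for compound 4. Compound 4 is estimated at 90000 nM, with a range from 30000 nM to 270000 nM.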

Compound 4, concentration for 50% growth inhibition: 8530 nM
For compound 4 the middle estimate is 11-fold (1.02 log units) above the measured one, and the stated range ends above it.
By their numbers in this assay, from the lowest: compound 4; then compound 1; then compounds 3 and 2 (each within the scatter of the next).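

With benzyloxy in place of fluoro, this assay shows a 7.2-fold lower number from compound 1 to compound 4 (0.86 log units; beyond the scatter), so this position, para to a large group, accepts a far larger substituent carrying an added aromatic ring, and the number falls. Among the changes shown, this is the only one to lower the number from compound 1, whereas both changes to the ring on the carbon double-bonded to nitrogen raised it. Nothing available explains the drop. The compounds shown leave open whether the added ring or its oxygen link accounts for the change. They also leave open how a methoxy group or an amine would read at this position.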